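The source may hold more compounds than are shown below. What is called first, only, known or untested is meant among the compounds shown, and "the series" means these compounds.

Measured so far:
compound 1, `Cc1c(-c2cc(-c3ccccc3)no2)cnn1C1CCNCC1`: 31%
compound 2, `Fc1cccc(Cl)c1-c1cc(-c2cnn(C3CCNCC3)c2)on1`: 60%

Both were tested in an assay on a protein complex for positive allosteric modulation of Neuronal acetylcholine receptor; alpha4/beta2 (Homo sapiens); a higher number here means a larger maximal response, a lower number a smaller maximal response. Compound 2 gives the higher of the two values with 60%, and its gap to compound 1 lies beyond the usual scatter. These two compounds differ in more than one place, so what each change adds on its own is not shown by the numbers.

Compound 3, `Cc1c(-c2cc(-c3c(F)cccc3Cl)no2)cnn1C1CCNCC1`, has not yet been measured. It differs from compound 2 in a single place: methyl in place of hydrogen on an aromatic carbon. Within the data shown here, no measured pair differs only in this way, so no measured step tells what this methyl group does here. The expected step is therefore small, a number 5 percentage points lower from compound 2 to compound 3 (within the scatter), meaning none beyond the scatter, with a slight downward lean since compound 1 also carries this methyl and gives only 31%. Compound 3 is thus estimated at 55%, in a range from 32% to 78%.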

Compound 3, largest response reached (reported as efficacy), in percent of the reference or control that the assay uses: 66%
Compound 3: middle estimate off by 11 percentage points, on the low side; the range from low to high includes it.
By their numbers in this assay, from the lowest: compound 1; then compounds 2 and 3 (each within the scatter of the next).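

Methyl in place of hydrogen on the aromatic carbon of the five-membered ring, next to the ring atom that bears the piperidin-4-yl group, gives in this assay a number 6 percentage points higher from compound 2 to compound 3 (within the scatter), so with 2-chloro-6-fluorophenyl present, this position takes a methyl group without a shift beyond the scatter. With that methyl shared, 2-chloro-6-fluorophenyl in place of phenyl gives a number 35 percentage points higher from compound 1 to compound 3 (beyond the scatter), which ties the low value of compound 1 to its phenyl group in this pair. Nothing available here gives a reason for either step.

On these data alone, whether this carbon would also accept a larger or different group, such as ethyl, methoxy or an amine, remains open. So does whether chlorine or fluorine alone on the phenyl ring would give the same large step.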